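Trifluoromethyl in Place of Methoxy: From Compound 1 to Compound 3

The source may hold more compounds than are shown below. What is called first, only, known or untested is meant among the compounds shown, and "the series" means these compounds.

Compound 1 `COc1cccc(-c2nc3cc(C)ccc3c(=O)[nH]2)c1`: 100%
Compound 2 `Cc1ccc2c(=O)[nH]c(-c3ccccc3F)nc2c1`: 81.2%

Of the compounds shown here, two on a shared core have been measured in an assay on isolated protein for inhibition of DNA topoisomerase 1 (Homo sapiens), with a stated time of 30 min, tested at 100 uM; on this read-out higher numbers stand for a stronger effect at the one concentration tested and lower numbers for a weaker effect. Compound 1 stands highest of the two numbers, and its nearest neighbour, compound 2, lies lower by a gap that is beyond the usual scatter. Within the data shown here, no pair of measured compounds differs in a single place, so no measured step is available to guide the next one.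

Compound 3 `Cc1ccc2c(=O)[nH]c(-c3cccc(C(F)(F)F)c3)nc2c1` is the compound still to be measured. It differs from compound 1 in one place: trifluoromethyl in place of methoxy on an aromatic carbon. Compound 1 sits at the top of what this read-out can report, so the step to compound 3 can only hold or fall. Among the measured compounds shown here, the trifluoromethyl group carries no hydrogen-bond acceptor, where the methoxy carried one, and the two measured compounds give no step from which the weight of that loss could be read. It is therefore expected that the step from compound 1 to compound 3 will be a number 15 percentage points lower from compound 1 to compound 3 (beyond the scatter), a small fall within or just beyond the scatter. Compound 3 is estimated to give 85%, in the range from 60% to 100%.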

Compound 3, a percentage reported as inhibition, at one concentration (the size of the read-out at that concentration, not a potency): 100%
Estimate against measurement, compound 3: 15 percentage points below, within the range that was stated.
By their numbers in this assay, from the lowest: compound 2; then compounds 1 and 3 (each within the scatter of the next).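

Among these compounds, replacing methoxy with trifluoromethyl on this aromatic carbon, meta to a large group, gives no change at the digits printed from compound 1 to compound 3 (within the scatter) in this assay and so shows what the earlier compounds could not: at this position, the read-out stays at the top of its range with either group, even though the hydrogen-bond acceptor counted on methoxy is absent from trifluoromethyl. The finding has a firm limit, since a single-concentration read-out at its top can show that this change causes no visible loss but cannot show that the two compounds would give an equally strong effect at other concentrations. Nothing measured here gives a reason for this result.

Any difference between compound 1 and compound 3 that lies hidden at the top of the read-out remains open, and only a comparison of the strength of their effect at lower concentrations could bring it out. As far as these compounds go, it also remains open whether the same aromatic carbon would keep the read-out at this level when carrying an amine, a carboxylic acid or a longer chain, or whether the result is particular to methoxy and trifluoromethyl.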